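Adding a 2-cyanophenyl group to a weak antiproliferative core

The source may hold more compounds than are shown below. What is called first, only, known or untested is meant among the compounds shown, and "the series" means these compounds.

Measured compounds:
compound 1 `COc1ccc2c(=O)c(-c3cc(OC)c(OC)cc3OC)coc2c1`: 9400 nM
compound 2 `COc1cc(OC)c(-c2coc3cc(OCc4ccc(Br)cc4)ccc3c2=O)cc1OC`: 10000 nM
compound 3 `COc1cc(OC)c(-c2coc3cc(OCc4ccccc4C)ccc3c2=O)cc1OC`: 2000 nM

In a functional assay on U-251 cells (Homo sapiens) for antiproliferative activity, read by MTT assay, with a stated time of 24 h (a higher number here means a weaker inhibitor, a lower number a stronger inhibitor), compound 1 gives 9400 nM, the second highest of the three numbers; compound 2 sits within the scatter of it, while compound 3 stands clearly lower. Compound 4 `COc1cc(OC)c(-c2coc3cc(OCc4ccccc4C#N)ccc3c2=O)cc1OC` differs from compound 1 as follows: 2-cyanophenyl in place of hydrogen on a saturated chain carbon bound to an oxygen on an aromatic ring. Going by the values given here, two measured steps bear on this change. The step of a 4.7-fold lower number from compound 1 to compound 3 (0.67 log units; beyond the scatter) shows that a 2-methylphenyl group on that carbon lowers the number; the step of a 1.1-fold higher number from compound 1 to compound 2 (0.03 log units; within the scatter) shows that a 4-bromophenyl group does not. The step from compound 1 to compound 4 is therefore expected to lie somewhere between these outcomes, most likely a modest lowering, as a 2.4-fold lower number from compound 1 to compound 4 (0.37 log units; beyond the scatter). Compound 4 is estimated at 4000 nM, with a range from 1500 nM to 11000 nM.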

Compound 4, half-maximal inhibitory concentration: 980 nM
Beside the measured number, compound 4's estimate is 4.1-fold (0.61 log units) above it; the measured number lies below the stated range.
By their numbers in this assay, from the lowest: compound 4; then compound 3; then compounds 1 and 2 (each within the scatter of the next).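

In this assay, a 2-cyanophenyl group on this carbon lowers the number more than either other group does, giving a 9.6-fold lower number from compound 1 to compound 4 (0.98 log units; beyond the scatter). Cyano in place of methyl on an aromatic carbon still gives a 2.0-fold lower number from compound 3 to compound 4 (0.31 log units; beyond the scatter), and replacing 4-bromophenyl gives a 10-fold lower number from compound 2 to compound 4 (1.01 log units; beyond the scatter), so the outcome depends on what the added ring carries, not on the ring alone. Nothing shown here explains these differences. Still open, from the compounds shown here alone, is whether a 4-cyanophenyl group would match the 2-cyanophenyl group, and how a carboxylic acid or an amine would fare in place of the cyano group.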